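Extending an Ester Chain in a Calcium Channel Antagonist Series

The source may hold more compounds than are shown below. What is called first, only, known or untested is meant among the compounds shown, and "the series" means these compounds.

Compound 1, `CCCCC1=C(C(=O)OCC)C(c2cccc([N+](=O)[O-])c2)C(C(=O)OCC)=C(C)N1`: 20 nM
Compound 2, `CCOC(=O)C1=C(C)NC(C)=C(C(=O)OCCOC)C1c1cccc([N+](=O)[O-])c1`: 82 nM

In a functional assay on HEK293 cells for antagonist activity at Voltage-dependent L-type calcium channel subunit alpha-1D (Rattus norvegicus), read by FLIPR (on this read-out higher numbers stand for weaker inhibition and lower numbers for stronger inhibition), compound 1 gives 20 nM, while compound 2 gives 82 nM. Compound 2 therefore shows the higher of the two numbers, and its distance from compound 1 lies beyond the usual scatter. Among the compounds with values here, no pair among the measured compounds differs in a single place, so no measured step is available.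

Compound 3, `C=C(C)C(=O)OCCOC(=O)C1=C(C)NC(C)=C(C(=O)OCC)C1c1cccc([N+](=O)[O-])c1`, has not yet been tested. It differs from compound 2 by (1-methylethenyl)carbonyl in place of methyl on an oxygen on a saturated carbon, so the ester chain grows at its far end while the remainder of the molecule stays as in compound 2.

Nothing in the measured set shows how such a lengthening of the chain acts in this assay, so the expectation rests on compound 2 alone. Compound 3 is expected to stay close to compound 2, because compound 2 gives 82 nM and the change lies away from the shared core. The estimated step of a 1.0-fold lower number from compound 2 to compound 3 (0.01 log units; within the scatter) is expected to fall within the scatter. The estimate for compound 3 is 80 nM, with a range from 30 nM to 250 nM.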

Compound 3, half-maximal inhibitory concentration: 10 nM
The estimate for compound 3 lay 8.0-fold (0.90 log units) above the measured number; measured number outside the range, below it.
By their numbers in this assay, from the lowest: compounds 3 and 1 (each within the scatter of the next); then compound 2.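

In this assay, (1-methylethenyl)carbonyl in place of methyl on an oxygen on a saturated carbon gives an 8.2-fold lower number from compound 2 to compound 3 (0.91 log units; beyond the scatter) and so moves the read-out toward stronger inhibition by a step beyond the scatter. The earlier compounds shown here could not show this, since no two of them differed in one place; this step shows that the far end of the ester chain is not a silent position and that a much larger group is accepted there, in this single pair at least. No measurement shown accounts for the size or direction of this step.

The compounds shown leave open whether the step belongs to the added carbonyl, to the 1-methylethenyl end or simply to the greater length of the chain, a question that an acetyl group, a saturated 2-methylpropanoyl group or a plain longer alkyl chain at the same place would help to separate. They also leave open how a terminal amine, a hydroxyl or a carboxylic acid would read at this position.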